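Working notes: trifluoromethyl in place of methyl

A few compounds are considered here, and "the series" means these few. Any claim that something is new, unique, unknown or untested is made for them only; others in the source may bear on it.

Values in a functional assay on MCF7 cells (Homo sapiens) for antiproliferative activity, read by MTT assay, with a stated time of 72 h (a lower number here means a stronger inhibitor, a higher number a weaker inhibitor), for the measured compounds follow
- compound 1 `C=CC/N=C1\S/C(=C\c2ccc(OC)cc2)C(=O)N1C` gives > 100000 nM (a limit of the assay, not a number)
- compound 2 `COc1ccc(/C=C2/CN(C)/C(=N/c3ccc(C)cc3)S2)cc1` gives 7600 nM (lower of the two numbers)
- compound 3 `COc1ccc(/C=C2\S/C(=N\c3ccc(Cl)cc3)N(C)C2=O)cc1` gives 39300 nM (higher of the two numbers)

Of the two true numbers, compound 2 holds the lower, and the gap to compound 3 lies beyond the scatter. The next compound to be read is compound 4 `COc1ccc(/C=C2/CN(C)/C(=N/c3ccc(C(F)(F)F)cc3)S2)cc1` (unmeasured), which differs from compound 2 in one place: trifluoromethyl in place of methyl on an aromatic carbon.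

Among the measured compounds shown here, only one measured step is available, namely an at least 2.5-fold lower number from compound 1 to compound 3 (0.40 log units; beyond the scatter) (4-chlorophenyl in place of allyl on a double-bonded nitrogen). That step replaces a whole group on the double-bonded nitrogen, so it bears only loosely on a swap on an aromatic carbon. Its size is also only a bound, as compound 1 stands at the limit of > 100000 nM in this assay, at which 1 of the 3 values shown sits (a limit). For the measured compounds named here, no measured step therefore sizes this change, and no step beyond the scatter is expected in this assay (no firm direction), though the range is kept wide. The expected change is small, an estimated 1.3-fold lower number from compound 2 to compound 4 (0.10 log units; within the scatter) (within the scatter). Estimated for compound 4 is 6000 nM (expected range 1800 nM to 20000 nM).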

Compound 4, half-maximal inhibitory concentration: 24100 nM
For compound 4 the middle estimate is 4.0-fold (0.60 log units) below the measured one; measured number outside the range, above it.
By their numbers in this assay, from the lowest: compound 2; then compounds 4 and 3 (each within the scatter of the next). At a limit, above all of these: compound 1.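

In this assay, among the compounds shown here, the only measured step at this position, on an aromatic carbon para to a large group, is a 3.2-fold higher number from compound 2 to compound 4 (0.50 log units; beyond the scatter). The earlier step, on the double-bonded nitrogen, rested on a limit and bore on a different place, whereas this one shows that the position is not indifferent to what it carries: methyl and trifluoromethyl, neither with a hydrogen-bond donor or acceptor and neither with a net charge, already read apart by more than the scatter. Nothing measured for these compounds speaks to what lies behind this step, so it stands as an observation only.

From the compounds shown here alone, two groups at this position give a single step and no trend, so how an amine, a carboxylic acid or a longer chain in the same place would read remains open. Also open, going by these compounds, is whether trifluoromethyl in place of methyl would give a similar step on the core of compound 3, since the step is known only on the core shared by compound 2 and compound 4.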